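The compounds below may be only part of what the source reports. "The series", "measured", "known", "first", "only" and "open" are said of these compounds alone.

Working notes on the series. All three measured compounds share one core and differ only in the aryl group on the alkene. In an ADME assay on cells (Macrophage, Homo sapiens) for cytotoxicity, read by MTT assay, with a stated time of 24 h (on this read-out higher numbers stand for lower toxicity in this test and lower numbers for higher toxicity in this test), compound 1 `COc1ccc(/C=C/c2ncc([N+](=O)[O-])n2CC(C)O)cc1` gives 560 nM. Compound 2 `CC(O)Cn1c([N+](=O)[O-])cnc1/C=C/c1ccc(Cl)cc1` gives 980 nM in this assay, the largest number among the three, though a 1.8-fold higher number from compound 1 to compound 2 (0.24 log units; within the scatter) is within the scatter. Compound 3 `CC(O)Cn1c([N+](=O)[O-])cnc1/C=C/c1ccc([N+](=O)[O-])cc1` gives 410 nM in this assay; a 2.4-fold lower number from compound 2 to compound 3 (0.38 log units; beyond the scatter) is beyond the scatter but modest, and a 1.4-fold lower number from compound 1 to compound 3 (0.14 log units; within the scatter) is within it. The swaps at that aromatic carbon thus moved the number little.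

Compound 4 `CC(O)Cn1c([N+](=O)[O-])cnc1/C=C/c1cccc(Br)c1` differs from compound 2 by 3-bromophenyl in place of 4-chlorophenyl on a double-bonded chain carbon bound to a double-bonded chain carbon. Within the data shown here, no measured step exchanges one halogen for another or shifts a substituent to a different ring position, so the only bearing comes from the small steps of a 1.8-fold higher number from compound 1 to compound 2 (0.24 log units; within the scatter) and a 2.4-fold lower number from compound 2 to compound 3 (0.38 log units; beyond the scatter). The expected step from compound 2 to compound 4 is therefore a 1.2-fold lower number from compound 2 to compound 4 (0.06 log units; within the scatter), that is, no step beyond the scatter in this assay. For compound 4 the estimate in this assay is 850 nM, with a range from 400 nM to 1900 nM.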

Compound 4, half-maximal cytotoxic concentration: 620 nM
Compound 4: middle estimate off by 1.4-fold (0.14 log units), on the high side, and the stated range covers the measured number.
By their numbers in this assay, from the lowest: compounds 3, 1, 4 and 2 (each within the scatter of the next, the first and the last beyond it).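

In this assay 3-bromophenyl in place of 4-chlorophenyl on a double-bonded chain carbon bound to a double-bonded chain carbon gives a 1.6-fold lower number from compound 2 to compound 4 (0.20 log units; within the scatter) and so stays within the scatter. The earlier compounds shown here covered only swaps at one aromatic carbon, whereas this change alters both the halogen and where it sits on the ring, and it still adds no step beyond the scatter. Nothing available explains the size of this step.

Among these compounds, the single step changes the halogen and its ring location together, so the share of each remains open. Also open, going by these compounds, is whether an amine or a carboxylic acid on the aryl group would move the number beyond the scatter.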